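This account rests on a few compounds, and the source may have more. Where it says the series, first, only, none or still open, it means among the compounds named here.

Measured in a functional assay on OVCAR-8 cells (Homo sapiens) for antiproliferative activity; on this read-out lower numbers stand for stronger inhibition and higher numbers for weaker inhibition:
- compound 1 `Cn1ncc(Cl)c1-c1cc(C(=O)N[C@@H]2CN[C@H](CCN3CCC(O)CC3)C[C@H]2c2ccc(Cl)c(Cl)c2)oc1Cl` gives 15900 nM
- compound 2 `Cn1ncc(Cl)c1-c1cc(C(=O)N[C@@H]2CN[C@H](CC(=O)O)C[C@H]2c2ccc(Cl)c(Cl)c2)oc1Cl` gives 5120 nM
- compound 3 `CN(C)CC[C@@H]1C[C@@H](c2ccc(Cl)c(Cl)c2)[C@H](NC(=O)c2cc(-c3c(Cl)cnn3C)c(Cl)o2)CN1` gives 1510 nM

Of these three, compound 3 has the lowest number, and its steps to both others lie beyond the scatter. In compound 4 `Cn1ncc(Cl)c1-c1cc(C(=O)N[C@@H]2CN[C@H](CC(=O)NC3CC3)C[C@H]2c2ccc(Cl)c(Cl)c2)oc1Cl`, cyclopropylcarbamoyl stands in place of (dimethylamino)methyl on a saturated chain carbon bound to a saturated ring carbon (cyclopropylcarbamoyl in place of (dimethylamino)methyl on a saturated chain carbon bound to a saturated ring carbon). Among the measured compounds shown here, no measured step makes this exact change, but two steps alter the same side chain. One is a 3.4-fold lower number from compound 2 to compound 3 (0.53 log units; beyond the scatter), and the other is an 11-fold lower number from compound 1 to compound 3 (1.02 log units; beyond the scatter). Compound 2 is the closer guide, since its carboxy group, like cyclopropylcarbamoyl, has a carbonyl at this place. Both steps favour compound 3, so a modest move back towards a higher number is expected in this assay, though the data contain no amide at this place to confirm it. The expected change is a 2.6-fold higher number from compound 3 to compound 4 (0.42 log units; beyond the scatter). For compound 4 the estimated value is 4000 nM, with an expected range of 1500 nM to 12000 nM.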

Compound 4, half-maximal inhibitory concentration: 580 nM
Compound 4: the middle estimate sits 6.9-fold (0.84 log units) above what was measured; measured number below the stated range.
By their numbers in this assay, from the lowest: compound 4; then compound 3; then compound 2; then compound 1.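

In this assay, an amine at the end of this side chain is not required for the lowest number, since an amide at this place goes further, with a 2.6-fold lower number from compound 3 to compound 4 (0.42 log units; beyond the scatter) in the change to cyclopropylcarbamoyl. Among the compounds shown here, the single change of cyclopropylamino in place of hydroxy on a carbonyl carbon gives an 8.8-fold lower number from compound 2 to compound 4 (0.95 log units; beyond the scatter) and so shows that a carbonyl at this place does not set the number alone: what is attached to it matters. The widest gap in the series is a 27-fold lower number from compound 1 to compound 4 (1.44 log units; beyond the scatter), and all three steps lie beyond the scatter, which leaves the amide lowest of the four.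

As far as these compounds go, whether the cyclopropyl ring itself contributes remains open, as the series holds neither methylcarbamoyl nor plain carbamoyl at this place. Nothing given here explains why these side chains differ as they do.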